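The source may hold more compounds than are shown below. What is called first, only, known or untested is meant among the compounds shown, and "the series" means these compounds.

In a functional assay on A549 cells (Homo sapiens) for inhibition, read by sulforhodamine B assay, with a stated time of 72 h; on this read-out lower numbers stand for stronger inhibition and higher numbers for weaker inhibition:
- compound 1 `Nc1sc(-c2ccc(Cl)cc2)c(-c2ccc(Cl)cc2)c1C(=O)NC1CCC1`: 12500 nM
- compound 2 `Nc1sc(-c2ccc(Cl)cc2)c(-c2ccc(Cl)cc2)c1C(=O)N1CCC(=O)CC1=O`: 4090 nM

Compound 2 holds the lower of the two numbers. Compound 3 `Nc1sc(-c2ccc(Cl)cc2)c(-c2ccc(Cl)cc2)c1C(=O)N1CCCC1` carries pyrrolidin-1-yl in place of 2,4-dioxopiperidin-1-yl on a carbonyl carbon. For the measured compounds named here, the one measured step at this place is modest: a 3.1-fold lower number from compound 1 to compound 2 (0.49 log units; beyond the scatter). Pyrrolidin-1-yl looks closer to the cyclobutylamino of compound 1, at 12500 nM, than to the group it replaces, so a partial return towards a higher number is expected in this assay, of about that size or smaller. The expected step is a 2.2-fold higher number from compound 2 to compound 3 (0.34 log units; beyond the scatter). For compound 3 the estimate is 9000 nM, with an expected range of 3500 nM to 25000 nM.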

Compound 3, half-maximal inhibitory concentration: 890 nM
For compound 3 the middle estimate is 10-fold (1.00 log units) above the measured one, outside the stated range (below it).
By their numbers in this assay, from the lowest: compound 3; then compound 2; then compound 1.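

In this assay, the group on the carbonyl carbon can lose both ring carbonyls of 2,4-dioxopiperidin-1-yl without any loss of inhibition, and the number falls further, with a 4.6-fold lower number from compound 2 to compound 3 (0.66 log units; beyond the scatter). The position also separates two small saturated groups sharply: cyclobutylamino and pyrrolidin-1-yl differ by a 14-fold lower number from compound 1 to compound 3 (1.15 log units; beyond the scatter), so this place is more sensitive than the first step suggested. Nothing available explains either step.

Ring size and the loss of the ring carbonyls change together from compound 2 to compound 3. Piperidin-1-yl would separate these two changes, while morpholin-4-yl would test a ring oxygen.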